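The source may hold more compounds than are shown below. What is called first, only, known or untested is meant among the compounds shown, and "the series" means these compounds.

Going by the values given here, compound 2 `O=C(O)c1ccccc1-c1ccc(CCc2ncc(Cc3ccc(F)cc3)[nH]2)cc1` stands at the lower of the two numbers so far in an in vitro functional assay on cells for agonist activity at Bombesin receptor subtype-3 (Homo sapiens), read by luminescence and calcium flux (on this read-out higher numbers stand for an effect only at larger amounts of compound and lower numbers for an effect already at smaller amounts), giving 1600 nM, while compound 1 `O=C(O)c1ccccc1-c1ccc(CCc2ncc(Cc3ccc(Cl)cc3)[nH]2)cc1` gives 2290 nM; the step of a 1.4-fold lower number from compound 1 to compound 2 (0.16 log units; within the scatter) separates them. Compound 3 `O=C(O)c1ccccc1-c1ccc(CCc2ncc(CC3CC3)[nH]2)cc1` differs from compound 2 by cyclopropyl in place of 4-fluorophenyl on a saturated chain carbon bound to an aromatic carbon. Among the compounds with values here, only the step from compound 1 to compound 2 is known, and it exchanges one halogen for another on the same ring; no measured step removes the aromatic ring itself, so it offers little guidance. The expected step of a 3.1-fold higher number from compound 2 to compound 3 (0.49 log units; beyond the scatter) is therefore uncertain, and compound 3 is estimated at 5000 nM, within 1500 nM to 16000 nM.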

Compound 3, half-maximal effective concentration: 1000 nM
The estimate for compound 3 lay 5.0-fold (0.70 log units) above the measured number; the whole stated range lies above it.
By their numbers in this assay, from the lowest: compounds 3, 2 and 1 (each within the scatter of the next, the first and the last beyond it).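

Exchanging the aromatic ring on the saturated chain carbon for cyclopropyl gives a 1.6-fold lower number from compound 2 to compound 3 (0.20 log units; within the scatter), so a group of 3 heavy atoms holds the level of 4-fluorophenyl with its 7. Against 4-chlorophenyl, the same exchange gives a 2.3-fold lower number from compound 1 to compound 3 (0.36 log units; beyond the scatter), the only step so far that lies beyond the scatter. No measurement at hand gives a reason for this result. The compounds shown leave open whether an ethyl group or an amine in place of cyclopropyl would keep this level.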